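Fluorophenyl piperazine succinimides in the electroshock model

The source may report more compounds than this note shows. Statements on the series, on what has been measured and on what is new or still open speak of the compounds shown alone.

Measured so far:
compound 1 `COc1cccc(N2CCN(C(=O)C(C)N3C(=O)CCC3=O)CC2)c1`: 0%
compound 2 `CC(C(=O)N1CCN(c2ccccc2F)CC1)N1C(=O)CCC1=O`: 50%
compound 3 `CC(C(=O)N1CCN(c2ccc(F)cc2)CC1)N1C(=O)CCC1=O`: 25%

In a functional assay on the whole organism (strain Swiss) with Mus musculus as the target, in the maximal electroshock model, with a stated time of 1 h, at a dose of 300 mg/kg by the intraperitoneal route (a lower number here means a weaker effect, a higher number a stronger effect of the compound at the dose given), compound 3 gives 25% and stands second highest of the three numbers; compound 1 lies a number 25 percentage points higher from compound 1 to compound 3 (beyond the scatter) away, compound 2 lies a number 25 percentage points lower from compound 2 to compound 3 (beyond the scatter) away, both beyond the scatter.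

Compound 4 `CC(C(=O)N1CCN(c2cccc(F)c2)CC1)N1C(=O)CCC1=O` is not yet measured. It differs from compound 3 by 3-fluorophenyl in place of 4-fluorophenyl on an amine nitrogen in a ring.

Within the data shown here, no measured step moves the fluorine to the place it takes in compound 4. Among the measured compounds shown here, the steps that bear on the change are those that move the fluorine on the same ring: a number 25 percentage points lower from compound 2 to compound 3 (beyond the scatter) and, against the shared methoxy-bearing reference, a number 50 percentage points higher from compound 1 to compound 2 (beyond the scatter) and a number 25 percentage points higher from compound 1 to compound 3 (beyond the scatter). These show that where the fluorine sits on the phenyl group changes the number by a modest to large amount, but they do not fix the direction for 3-fluorophenyl. The step of a number 10 percentage points higher from compound 3 to compound 4 (within the scatter) is therefore expected to be small, within or near the scatter, with a wide range. Compound 4 is estimated at 35%, between 10% and 60%.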

Compound 4, a percentage reported as activity, at one dose (the size of the read-out at that dose, not a potency): 75%
Compound 4: the middle estimate sits 40 percentage points below what was measured, outside the stated range (above it).
By their numbers in this assay, from the lowest: compound 1; then compound 3; then compound 2; then compound 4.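

Notes on the fluorine position: in this assay the change to 3-fluorophenyl gives a number 50 percentage points higher from compound 3 to compound 4 (beyond the scatter) and also a number 25 percentage points higher from compound 2 to compound 4 (beyond the scatter), so the place of a single fluorine on this phenyl group separates all three fluoro compounds by steps beyond the scatter, with compound 4 highest of the series. The replacement of methoxy by fluoro on an aromatic carbon gives a number 75 percentage points higher from compound 1 to compound 4 (beyond the scatter), the largest step printed for the series. Nothing measured here accounts for this order of the three fluorophenyl compounds.

Open, on these data alone, is whether chloro or trifluoromethyl in place of fluoro on the 3-substituted phenyl group holds the number seen for compound 4. The compounds shown also leave open how a methoxy group at each of the other ring places compares with its fluoro counterpart.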